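Cyclobutyl in Place of But-2-yn-1-yl on the Shared Core

The source may report more compounds than this note shows. Statements on the series, on what has been measured and on what is new or still open speak of the compounds shown alone.

Measured compounds:
compound 1, `CC[C@H](C)Cn1c(Cc2cc(OC)c(OC)c(OC)c2)nc2c(N)nc(F)nc21`, 66700000 nM
compound 2, `CC#CCCn1c(Cc2cc(OC)c(OC)c(OC)c2)nc2c(N)nc(F)nc21`, 95500000 nM

In a functional assay on MCF7 cells (Homo sapiens) for cytotoxicity (a higher number here means that more compound is needed for the effect, a lower number that less compound is needed), compound 1 gives 66700000 nM, while compound 2 gives 95500000 nM. Among the measured compounds shown here, compound 2 is one of only two measured compounds, and its sole neighbour is compound 1; the step of a 1.4-fold higher number from compound 1 to compound 2 (0.16 log units; within the scatter) leaves the pair within the scatter of each other, so neither number stands apart from the other.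

Compound 3, `COc1cc(Cc2nc3c(N)nc(F)nc3n2CC2CCC2)cc(OC)c1OC`, differs from compound 2 by cyclobutyl in place of but-2-yn-1-yl on a saturated chain carbon bound to an aromatic nitrogen. For the measured compounds named here, the only measured step that bears on this place is a 1.4-fold higher number from compound 1 to compound 2 (0.16 log units; within the scatter), where exchanging one chain for another at the same saturated carbon on the aromatic nitrogen produced no shift beyond the scatter. On that basis the exchange for cyclobutyl is expected to give no step beyond the scatter either, a 1.1-fold lower number from compound 2 to compound 3 (0.05 log units; within the scatter). Compound 3 is therefore estimated at 85000000 nM, with a range from 30000000 nM to 240000000 nM.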

Compound 3, half-maximal effective concentration: 109000000 nM
Estimate against measurement, compound 3: 1.3-fold (0.11 log units) below; the range from low to high includes it.
By their numbers in this assay, from the lowest: compounds 1, 2 and 3 (each within the scatter of the next).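

In this assay, among the compounds shown here, a ring enters this place for the first time, and the new steps read a 1.1-fold higher number from compound 2 to compound 3 (0.06 log units; within the scatter) and a 1.6-fold higher number from compound 1 to compound 3 (0.21 log units; within the scatter). Cyclobutyl, but-2-yn-1-yl and sec-butyl, on a saturated chain carbon bound to an aromatic nitrogen, therefore leave compounds 1, 2 and 3 all within the scatter of one another, so neither the one-ring group nor the triple bond sets any of these compounds apart. Nothing available accounts for how closely these numbers lie together.

On these data alone, whether an amine, a carboxylic acid or a longer chain at this place would give a step beyond the scatter stays open. So does whether a change elsewhere on the shared core would shift the number in this assay at all.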